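The source may report more compounds than this note shows. Statements on the series, on what has been measured and on what is new or still open speak of the compounds shown alone.

In a functional assay on RS4-11 cells (Homo sapiens) for inhibition, read by CCK-8 assay, with a stated time of 48 h, tested at 20 uM (on this read-out higher numbers stand for more inhibition of growth at the one concentration tested and lower numbers for less inhibition of growth), compound 1 (`N#C/C(=C\c1ccccc1OS(=O)(=O)c1ccc(F)cc1)C(=O)Nc1nnc(Cc2cccc3ccccc23)s1`) gives 68% and compound 2 (`COc1ccc(S(=O)(=O)Oc2ccccc2/C=C(\C#N)C(=O)Nc2nnc(Cc3ccc(Cl)cc3)s2)cc1`) gives 77% on the same read-out. These two numbers lie within the usual scatter of each other, so compound 2 stands level with compound 1 on the data so far. Compound 3 (`N#C/C(=C\c1ccccc1OS(=O)(=O)c1ccc(F)cc1)C(=O)Nc1nnc(Cc2ccc(Cl)cc2)s1`) differs from compound 2 in one place, with fluoro in place of methoxy on an aromatic carbon, para to a large group (fluoro in place of methoxy on an aromatic carbon). Within the data shown here, no two measured compounds differ in one place only, so no measured step shows what this exchange does. The 4-fluorophenyl group does occur in compound 1, which gives 68% but also differs from compound 3 elsewhere. The estimated step of a number 5 percentage points lower from compound 2 to compound 3 (within the scatter) is small, downward and within the scatter. For compound 3 the estimated value is 72% with an expected range of 58% to 85% in this measurement.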

Compound 3, percent growth inhibition at one concentration: 64%
Beside the measured number, compound 3's estimate is 8 percentage points above it, and the stated range covers the measured number.
By their numbers in this assay, from the lowest: compounds 3, 1 and 2 (each within the scatter of the next, the first and the last beyond it).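

In this assay the change from 4-methoxyphenyl to 4-fluorophenyl gives the first step read at this position: the result is a number 13 percentage points lower from compound 2 to compound 3 (beyond the scatter) and counts as a modest loss of growth inhibition. Among these compounds, the exchange of naphthalen-1-yl for 4-chlorophenyl gives a number 4 percentage points lower from compound 1 to compound 3 (within the scatter) and so does not separate those two groups on this read-out, which leaves the methoxy to fluoro exchange as the only one of the two steps that goes beyond the scatter. Nothing measured here bears on why the methoxy to fluoro step goes this way.

One step cannot tell whether methoxy raises the number or fluoro lowers it. As far as these compounds go, how an amine or a trifluoromethyl group at this position would read stays open, as does whether the step holds with naphthalen-1-yl in place of 4-chlorophenyl.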